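Replacing 3-bromophenyl with pyridin-3-yl in the series

The source may report more compounds than this note shows. Statements on the series, on what has been measured and on what is new or still open speak of the compounds shown alone.

In an ADME assay on the whole organism for cytotoxicity, with Artemia salina as the target, with a stated time of 24 h (on this read-out lower numbers stand for an effect already at smaller amounts and higher numbers for an effect only at larger amounts of compound), compound 1 (`Cc1ccc(S(=O)(=O)NC(=O)Nc2ccccc2C(=O)/C=C/c2ccccc2O)cc1`) gives 32.3 ug/mL and compound 2 (`Cc1ccc(S(=O)(=O)NC(=O)Nc2ccccc2C(=O)/C=C/c2cccc(Br)c2)cc1`) gives 4.02 ug/mL, the lower of the two numbers. Compound 3 (`Cc1ccc(S(=O)(=O)NC(=O)Nc2ccccc2C(=O)/C=C/c2cccnc2)cc1`) carries pyridin-3-yl in place of 3-bromophenyl on a double-bonded chain carbon bound to a double-bonded chain carbon. For the measured compounds named here, the only measured change at this place is an 8.0-fold lower number from compound 1 to compound 2 (0.90 log units; beyond the scatter), and it lies beyond the scatter. Going by the values given here, no measured compound carries pyridin-3-yl, so that step is only a rough guide to size. The expected step is a 3.0-fold higher number from compound 2 to compound 3 (0.47 log units; beyond the scatter), towards a higher number in this assay. For compound 3 the estimated value is 12 ug/mL, with an expected range of 3.5 ug/mL to 45 ug/mL.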

Compound 3, concentration for half-maximal effect: 14.1 ug/mL
For compound 3 the middle estimate is 1.2-fold (0.07 log units) below the measured one, and the stated range covers the measured number.
By their numbers in this assay, from the lowest: compound 2; then compound 3; then compound 1.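

At this place, on a double-bonded chain carbon bound to a double-bonded chain carbon, three ring groups now give three separate levels in this assay. Pyridin-3-yl gives a 3.5-fold higher number from compound 2 to compound 3 (0.54 log units; beyond the scatter) and still a 2.3-fold lower number from compound 1 to compound 3 (0.36 log units; beyond the scatter), so the change away from 3-bromophenyl does not return the number to the level of 2-hydroxyphenyl. Nothing measured accounts for either step.

The compounds shown leave open how plain phenyl or 3-aminophenyl would read at this place. They also leave open whether the bromine itself carries the low number of compound 2.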